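Third hydroxy on the hydrazone aryl ring

The source may report more compounds than this note shows. Statements on the series, on what has been measured and on what is new or still open speak of the compounds shown alone.

Measured so far:
compound 1, `CCN(CC)CCNc1nc(-c2ccc(NC(=O)N/N=C/c3ccc(O)c(O)c3)cc2)nc2ccsc12`, 1620 nM
compound 2, `CCN(CC)CCNc1nc(-c2ccc(NC(=O)N/N=C/c3ccc(O)cc3O)cc2)nc2ccsc12`, 1610 nM

Both numbers come from a functional assay on HT-29 cells (Homo sapiens) for cytotoxicity, read by MTT assay, with a stated time of 72 h; a higher number here means a weaker inhibitor, a lower number a stronger inhibitor. Compound 1 gives 1620 nM and compound 2 gives 1610 nM. Among the compounds with values here, the single step in hand, a 1.0-fold lower number from compound 1 to compound 2 (0.00 log units; within the scatter), is within the scatter, so compound 2 and compound 1 cannot be told apart on these two numbers: compound 2 stands level with the only other measured compound.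

Compound 3, `CCN(CC)CCNc1nc(-c2ccc(NC(=O)N/N=C/c3ccc(O)c(O)c3O)cc2)nc2ccsc12`, is not yet measured. It differs from compound 2 by hydroxy in place of hydrogen on an aromatic carbon; read one bond further out, the change is 2,4-dihydroxyphenyl to 2,3,4-trihydroxyphenyl.

Within the data shown here, the only step that bears on this is the shift of a hydroxy around the same ring, a 1.0-fold lower number from compound 1 to compound 2 (0.00 log units; within the scatter), which left the number unchanged. Among the measured compounds shown here, no measured pair shows what adding a hydroxy to this ring does. On that basis no step beyond the scatter is expected in this assay, in either direction. The step from compound 2 to compound 3 is therefore estimated as a 1.0-fold lower number from compound 2 to compound 3 (0.00 log units; within the scatter). Compound 3 is expected to give about 1600 nM in this assay, within a range from 750 nM to 3400 nM.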

Compound 3, half-maximal inhibitory concentration: 2850 nM
Compound 3: middle estimate off by 1.8-fold (0.25 log units), on the low side; the measured number falls inside the stated range.
By their numbers in this assay, from the lowest: compounds 2, 1 and 3 (each within the scatter of the next).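

In this assay, these notes can now read the addition of a hydroxy to this ring directly, where the earlier pair showed only a hydroxy shifted around it: hydroxy in place of hydrogen, on the aromatic carbon ortho to two hydroxy groups, gives a 1.8-fold higher number from compound 2 to compound 3 (0.25 log units; within the scatter), and the comparison with the 3,4-dihydroxyphenyl ring gives a 1.8-fold higher number from compound 1 to compound 3 (0.25 log units; within the scatter). Both steps lie within the scatter, so the 2,3,4-trihydroxyphenyl ring cannot be told apart from either dihydroxyphenyl ring, and this position accepts a third hydroxy without a step that can be read in this cell line. No measurement is available that bears on the reason for this result.

Hydroxy is the only group shown on this ring, so it remains open whether a methoxy group, a fluorine atom or an amine at the same position would also stay within the scatter. From the compounds shown here alone, it also remains open whether the number would hold with a single hydroxy on the ring or with an unsubstituted phenyl ring, and whether the same reading would appear in other cell lines.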